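The source may hold more compounds than are shown below. What is called first, only, known or untested is meant among the compounds shown, and "the series" means these compounds.

The account concerns a small set of compounds sharing one core and tested in an assay for inhibition of Indoleamine 2,3-dioxygenase 1 (Homo sapiens), with stated times of 10 min and 60 min, tested at 100 uM; on this read-out lower numbers stand for a weaker effect and higher numbers for a stronger effect at the one concentration tested. Compound 1 `O=C(O)CNc1cccc(CNc2cc(C(F)(F)F)cc3[nH]ncc23)c1` gives 8% in this assay, which is the lowest of the three numbers shown. Compound 3 `O=[N+]([O-])c1ccccc1CNc1cc(Br)cc2[nH]ncc12` gives 83% in this assay, a reading far beyond the scatter above compound 1. Compound 2 `O=[N+]([O-])c1ccc(CNc2cc(Br)cc3[nH]ncc23)cc1` gives 87% in this assay, again well beyond the scatter above compound 1. For the measured compounds named here, no pair of these measured compounds differs in a single place, so no measured step can be drawn between them.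

Compound 4 `FC(F)(F)c1cc(NCc2cccc(Br)c2)c2cn[nH]c2c1` has not yet been measured in this assay. It differs from compound 1 in one respect: bromo in place of (carboxymethyl)amino on an aromatic carbon. Both compound 2 and compound 3 carry a bromo group and neither carries a (carboxymethyl)amino group, and both give high readings, whereas compound 1 carries the (carboxymethyl)amino group and gives a low reading. On that basis the expected step in this assay is upward and sizeable, well beyond the scatter, though the exact size is uncertain because the group in compound 4 sits on a different ring than in compound 2 or compound 3. The estimated step of a number 47 percentage points higher from compound 1 to compound 4 (beyond the scatter) reflects this. For compound 4 the expected value in this assay is 55%, with a range from 20% to 85%.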

Compound 4, a percentage reported as inhibition, at one concentration (the size of the read-out at that concentration, not a potency): 51%
Estimate against measurement, compound 4: 4 percentage points above; the measured number falls inside the stated range.
By their numbers in this assay, from the lowest: compound 1; then compound 4; then compounds 3 and 2 (each within the scatter of the next).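

In this assay, for the compounds shown here, the replacement of (carboxymethyl)amino by bromo on an aromatic carbon, meta to a large group, gives a number 43 percentage points higher from compound 1 to compound 4 (beyond the scatter) and is the first single-place comparison available in this set. It shows that the reading responds to the group at this position while the rest of compound 1 stays unchanged, including the trifluoromethyl group on the shared core. The change removes a chain carrying hydrogen-bond donors and acceptors and puts a single bromine atom in its place, but no accompanying measurement identifies which of these differences matters, and nothing shown gives the step a cause.

On these data alone, it remains open whether the step is particular to bromo or would also appear with a chloro, methyl or methoxy group, a plain amine, or a carboxylic acid on a longer chain at this place. Also open is how far the reading of compound 4 depends on its trifluoromethyl group, as no compound shown differs from it at that place alone.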